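Aryl substituent variation in the series

The compounds below may be only part of what the source reports. "The series", "measured", "known", "first", "only" and "open" are said of these compounds alone.

Compound 1 `CC1CCN(C2CCN(S(=O)(=O)c3ccc(C#N)cc3)CC2)CC1` gives 2800 nM in a functional assay on DLD-1 cells (Homo sapiens) for antiproliferative activity, read by CellTiter-Glo, with a stated time of 72 h; on this read-out lower numbers stand for stronger inhibition and higher numbers for weaker inhibition. Compound 2 `CC1CCN(C2CCN(S(=O)(=O)c3ccc(C(C)C)cc3)CC2)CC1` gives 685 nM in this assay and stands lowest of the two numbers. For the measured compounds named here, the only measured step is a 4.1-fold lower number from compound 1 to compound 2 (0.61 log units; beyond the scatter). Compound 3 `CCCCOc1ccc(S(=O)(=O)N2CCC(N3CCC(C)CC3)CC2)cc1` is not yet measured; the change is butoxy in place of isopropyl on an aromatic carbon. The measured step bears on it only loosely, as it exchanged a nitrile for an isopropyl, whereas here an isopropyl gives way to a butoxy, so at most a small step downward is expected: a 1.4-fold lower number from compound 2 to compound 3 (0.14 log units; within the scatter). Compound 3 is therefore expected to give 500 nM in this assay, within 150 nM to 1600 nM.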

Compound 3, half-maximal inhibitory concentration: 2300 nM
Beside the measured number, compound 3's estimate is 4.6-fold (0.66 log units) below it; the whole stated range lies below it.
By their numbers in this assay, from the lowest: compound 2; then compounds 3 and 1 (each within the scatter of the next).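

On this aromatic carbon, para to a large group, butoxy does not extend the drop in number seen with isopropyl: in this assay there is a 3.4-fold higher number from compound 2 to compound 3 (0.53 log units; beyond the scatter). Butoxy cannot be separated from the nitrile, with a 1.2-fold lower number from compound 1 to compound 3 (0.09 log units; within the scatter), so compound 2 alone stands out among the three. Nothing available explains the reversal. Open, going by these compounds, is whether the ether oxygen or the chain length of butoxy governs this step, as methoxy or a plain butyl group would show. Also open, on these data alone, is how an amine or a carboxylic acid behaves at this carbon.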